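The source may report more compounds than this note shows. Statements on the series, on what has been measured and on what is new or still open speak of the compounds shown alone.

Measured in a functional assay on HCT-116 cells (Homo sapiens) for cytotoxicity, read by MTT assay, with a stated time of 48 h; a lower number here means a stronger inhibitor, a higher number a weaker inhibitor:
compound 1 `O=C(/C=C/c1ccc2c(c1)B(O)OC2)c1cccs1` gives 14200 nM
compound 2 `O=C(/C=C/c1ccc2c(c1)B(O)OC2)c1ccc(Cl)cc1` gives 9300 nM
compound 3 `O=C(/C=C/c1ccc2c(c1)B(O)OC2)c1ccc(OCc2ccccc2)cc1` gives 12100 nM

Compound 3 sits second highest of the three numbers; its nearest neighbour is compound 1 and its furthest compound 2, and both of those gaps lie within the scatter, so on these numbers the three compounds are not separated from one another.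

Compound 4 `Nc1ccc(C(=O)/C=C/c2ccc3c(c2)B(O)OC3)cc1` differs from compound 3 in one place: amino in place of benzyloxy on an aromatic carbon. Going by the values given here, two measured steps bear on this. a 1.5-fold lower number from compound 1 to compound 2 (0.18 log units; within the scatter) exchanged the whole ring on the carbonyl carbon; a 1.3-fold higher number from compound 2 to compound 3 (0.11 log units; within the scatter) exchanged the substituent on that ring. Both were within the scatter. Among the compounds with values here, no measured compound carries a group with a hydrogen-bond donor on that ring, so the step to an amino group is not covered directly, but nothing so far indicates that changes on the ring at the carbonyl carbon move the number beyond the scatter. The step from compound 3 to compound 4 is therefore expected to be small, a 1.1-fold lower number from compound 3 to compound 4 (0.04 log units; within the scatter), with no firm direction. For compound 4 the estimate in this assay is 11000 nM, with a range from 4000 nM to 30000 nM.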

Compound 4, half-maximal inhibitory concentration: 26100 nM
Compound 4: middle estimate off by 2.4-fold (0.38 log units), on the low side; the measured number falls inside the stated range.
By their numbers in this assay, from the lowest: compounds 2, 3, 1 and 4 (each within the scatter of the next, the first and the last beyond it).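

In this assay, going by these compounds alone, amino is the first group at this place, para to a large group, to give a step beyond the scatter: a 2.2-fold higher number from compound 3 to compound 4 (0.33 log units; beyond the scatter) and a 2.8-fold higher number from compound 2 to compound 4 (0.45 log units; beyond the scatter), both modest and both toward a weaker inhibitor, whereas chloro and benzyloxy at the same place could not be told apart. The ring on the carbonyl carbon is therefore not without effect on this read-out, although the effect remains limited: a 1.8-fold higher number from compound 1 to compound 4 (0.26 log units; within the scatter) stays within the scatter, so compound 4 is not separated from the thiophen-2-yl compound. No measurement available here accounts for the shift.

Still open, on these data alone, is whether the step belongs to amino alone or extends to other groups with a hydrogen-bond donor at this place, which a hydroxyl, a methylamino or an acetamide group there would help to settle. Also open, as far as these compounds go, is whether a dimethylamino group or a carboxylic acid at the same place would move the number further, or return it to the level of compound 2 and compound 3.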